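Benzylamine sulfonamides on pancreatic cancer cells: dropping the chloro

The source may hold more compounds than are shown below. What is called first, only, known or untested is meant among the compounds shown, and "the series" means these compounds.

Two compounds of this series carry numbers in a functional assay on PANC-1 cells (Homo sapiens) for inhibition, read by MTT assay, with a stated time of 72 h; on this read-out lower numbers stand for stronger inhibition of growth and higher numbers for weaker inhibition of growth. Compound 1 `O=S(=O)(NCCCNCc1cccc(Cl)c1)c1cc(C(F)(F)F)cc(C(F)(F)F)c1` gives 12000 nM, and compound 2 `O=S(=O)(NCCNCc1cccc2ccccc12)c1cc(C(F)(F)F)cc(C(F)(F)F)c1` gives 24000 nM. Compound 1 holds the lower of the two numbers, but its gap to compound 2 lies within the usual scatter of repeated measurements, so no distinction between the two is drawn. Within the data shown here, no pair of measured compounds differs in one place only, so no single-change step is known.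

Compound 3 `O=S(=O)(NCCCNCc1ccccc1)c1cc(C(F)(F)F)cc(C(F)(F)F)c1` has not been measured. It differs from compound 1 in one place: hydrogen in place of chloro on an aromatic carbon. Removing a chloro from the benzyl part of compound 1 is a small change in a region with no measured reference, and nothing shown supports a change beyond the scatter. The expected step from compound 1 to compound 3 is a 1.5-fold higher number from compound 1 to compound 3 (0.18 log units; within the scatter), none beyond the scatter, leaning if anything toward weaker growth inhibition. For compound 3 the estimate in this assay is 18000 nM, with a range from 7000 nM to 45000 nM.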

Compound 3, concentration for 50% growth inhibition: 16000 nM
Compound 3: the middle estimate sits 1.1-fold (0.05 log units) above what was measured; low and high end bracket the measured number.
By their numbers in this assay, from the lowest: compounds 1, 3 and 2 (each within the scatter of the next).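

In this assay the series gains its first single-change step, from 3-chlorobenzyl to benzyl (a 1.3-fold higher number from compound 1 to compound 3 (0.12 log units; within the scatter)). At this place, on an aromatic carbon meta to a large group, loss of the chloro leaves a difference that this read-out cannot separate from scatter, so the chloro is not shown to matter for growth inhibition at this level. Nothing measured bears on the reason for this result.

Going by these compounds, whether a methoxy, a nitrile or a carboxylic acid on the same carbon would move the number beyond the scatter remains open. The contribution of the chain also remains open, since no compounds shown differ there alone, and a longer chain is one case that could separate it.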